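The compounds below may be only part of what the source reports. "The series", "measured", "known", "first", "only" and "open" are said of these compounds alone.

Compound 1 `CCCSc1nc(C(C)c2c(F)cccc2Cl)c(C)c(=O)[nH]1`: in an ADME assay on MT4 cells (Homo sapiens) for activation, read by MTT assay (on this read-out higher numbers stand for lower toxicity in this test and lower numbers for higher toxicity in this test), compound 1 gives only a limit, > 1500 nM.
Compound 2 `CCC(c1nc(SC(C)C)[nH]c(=O)c1C)c1c(F)cccc1Cl`: in this assay compound 2 gives only a limit, > 3000 nM.
Compound 3 `CCCSc1nc(C(C)c2c(F)cccc2F)c(C)c(=O)[nH]1`: in this assay compound 3 gives only a limit, > 3000 nM.

Compound 1 and compound 3 differ in one place, (fluoro in place of chloro on an aromatic carbon). The step that the two limits leave unreadable from compound 1 to compound 3 has no readable size, since both values are limits. Compound 1 sits at the limit of > 1500 nM in this assay, at which 1 of the 3 values shown sits. Compound 3 sits at the limit of > 3000 nM in this assay, at which 2 of the 3 values shown sit. Compound 2 and compound 1 differ in their cores; the difference between the two cores is not broken down here.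

Compound 4 `CCC(c1nc(SC(C)C)[nH]c(=O)c1C)c1c(F)cccc1F` has not yet been measured in this assay. For the measured compounds named here, it differs from compound 2 by fluoro in place of chloro on an aromatic carbon, the same change, at the same place, as the one made from compound 1 to compound 3. Compound 4 is expected to give 5000 nM, and most likely again only as a limit. The expected step that the limit leaves unreadable from compound 2 to compound 4 is set to mirror the unreadable step that the two limits leave unreadable from compound 1 to compound 3. That expectation rests on compound 2, whose value is a limit, > 3000 nM.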

Compound 4, half-maximal cytotoxic concentration: > 30000 nM
Compound 4: no number, only a limit; the forecaster's own chance of this, stated with the estimate: 80%; middle value at least 6.0-fold (0.77 log units) away from the limit.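

For the compounds shown here, compound 2 and compound 4 both give only limits in this assay, so no step between them can be read, just as none can be read between compound 1 and compound 3. The compounds shown leave open the actual half-maximal cytotoxic concentration of all four, and whether fluoro in place of chloro on an aromatic carbon changes it in either pair.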